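The source may report more compounds than this note shows. Statements on the series, on what has been measured and on what is new or still open speak of the compounds shown alone.

Working notes on the shared core. Compound 1 `Cc1ccccc1Nc1nc(C)c(C(=O)/C=C/c2ccccc2Cl)s1` is tested in a functional assay on BGC-823 cells (Homo sapiens) for cytotoxicity, read by MTT assay; on this read-out lower numbers stand for stronger inhibition and higher numbers for weaker inhibition; in this assay compound 1 gives only a limit of the assay, > 25000 nM, and not a number. Compound 2 `COc1cc(/C=C/C(=O)c2sc(Nc3ccc(Cl)c(Cl)c3)nc2C)cc(OC)c1OC` likewise returns a limit in this assay: compound 2 shows > 25000 nM, which is also no number. Where compound 2 stands is thus the limit itself, since both shown values sit at the limit of > 25000 nM in this assay, at which 2 of the 2 values shown sit, and no step between measured compounds can be drawn from two limits. Compound 3 `COc1cc(/C=C/C(=O)c2sc(Nc3ccc(F)c(Cl)c3)nc2C)cc(OC)c1OC` follows from compound 2 by fluoro in place of chloro on an aromatic carbon. The exchange is confined to one substituent position on the outer ring of the anilino part, and nothing in the two shown values gives any ground on which a change in activity could be foreseen. With only limits to anchor it, no movement beyond the scatter is expected in this assay; the expected step is a step that the limit leaves unreadable from compound 2 to compound 3. Compound 3 is estimated at 35000 nM, with a range from 12000 nM to 100000 nM, and the more likely outcome is again a limit rather than a number.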

Compound 3, half-maximal inhibitory concentration: 9700 nM
For compound 3 the middle estimate is 3.6-fold (0.56 log units) above the measured one; measured number below the stated range.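

In this assay, replacing the 3,4-dichlorophenyl group with the 3-chloro-4-fluorophenyl group gives an at least 2.5-fold lower number from compound 2 to compound 3 (0.41 log units; beyond the scatter), so this position, para to a large group and ortho to a chloro group, can shift the read-out out of the limit and into a measurable range. The change is a single halogen exchange, one heavy atom for one heavy atom, with no ring, hydrogen-bond donor, hydrogen-bond acceptor or net charge entering or leaving, and that alone is enough to produce a step beyond the scatter. The full size of the step cannot be read, as one end of it is a limit of the assay and not a number: the limit of > 25000 nM in this assay, at which 2 of the 3 values shown sit.

The compounds shown leave open whether the read-out moves further with hydrogen, a methoxy group, an amine or a carboxylic acid on this same ring carbon. They also leave open whether fluoro in place of chloro gives a step of similar size when the rest of the shared core carries other groups, such as the 2-chlorophenyl group of compound 1.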